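The source may hold more compounds than are shown below. What is called first, only, known or untested is meant among the compounds shown, and "the series" means these compounds.

Working notes on the series.

For the measured compounds named here, compound 3 `O=C(O)CCC/C=C\C[C@H]1[C@@H]2CCC(C2)[C@@H]1NS(=O)(=O)Cc1ccccc1` is the weakest of the three measured members in a functional assay (plasma) for inhibition, with Oryctolagus cuniculus as the target; on this read-out lower numbers stand for stronger inhibition and higher numbers for weaker inhibition: compound 3 gives 113000 nM. The nearest measured neighbour is compound 1 `CCCCCCS(=O)(=O)N[C@H]1C2CC[C@H](C2)[C@@H]1C/C=C\CCCC(=O)O`, which in this assay gives 13300 nM, with an 8.5-fold higher number from compound 1 to compound 3 (0.93 log units; beyond the scatter). The furthest is compound 2 `O=C(O)CCC/C=C\C[C@H]1[C@@H]2CCC(C2)[C@@H]1NS(=O)(=O)c1ccc(F)cc1`, which in this assay gives 600 nM, with a 190-fold higher number from compound 2 to compound 3 (2.27 log units; beyond the scatter).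

Compound 4 `O=C(O)CCC/C=C\C[C@H]1[C@@H]2CCC(C2)[C@@H]1NS(=O)(=O)c1ccc(O)cc1` is not yet measured. The change from compound 3: 4-hydroxyphenyl in place of benzyl on a sulfonyl sulfur. Going by the values given here, the step that bears most directly on this is the one from compound 2 to compound 3, where an aryl group bound straight to the sulfonyl sulfur was exchanged for benzyl and a 190-fold higher number from compound 2 to compound 3 (2.27 log units; beyond the scatter); the step from compound 1 to compound 2, with a 22-fold lower number from compound 1 to compound 2 (1.35 log units; beyond the scatter), also shows an aryl on the sulfonyl sulfur giving the lowest number of the set. Among the compounds with values here, compound 4 returns an aryl to that sulfur, so a large step down in this assay is expected, though no measured pair tells how 4-hydroxyphenyl compares with 4-fluorophenyl, which leaves the size uncertain. Compound 4 is therefore estimated at 2500 nM, within 400 nM to 15000 nM, which would mean an expected 45-fold lower number from compound 3 to compound 4 (1.66 log units; beyond the scatter).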

Compound 4, half-maximal inhibitory concentration: 500 nM
The estimate for compound 4 lay 5.0-fold (0.70 log units) above the measured number; low and high end bracket the measured number.
By their numbers in this assay, from the lowest: compounds 4 and 2 (each within the scatter of the next); then compound 1; then compound 3.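

In this assay, hydroxy in place of fluoro on an aromatic carbon makes no readable difference, with a 1.2-fold lower number from compound 2 to compound 4 (0.08 log units; within the scatter), so these two aryl groups are not separated at this position. The other two steps, a 230-fold lower number from compound 3 to compound 4 (2.35 log units; beyond the scatter) and a 27-fold lower number from compound 1 to compound 4 (1.42 log units; beyond the scatter), show that the low numbers are not confined to the 4-fluorophenyl group: both aryl groups bound straight to the sulfonyl sulfur stand clear of benzyl and hexyl, and none of the four compounds goes against this. No measurement bearing on the reason for this result is available.

Still open, from the compounds shown here alone, is whether an unsubstituted phenyl on the sulfonyl sulfur would give a similar number. It is also unknown whether an amine, a methoxy group or a carboxylic acid in place of the hydroxy would preserve it.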